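The source may hold more compounds than are shown below. What is called first, only, known or untested is meant among the compounds shown, and "the series" means these compounds.

Compound 1 `COc1c(OC(C)C)cc2occ(-c3ccccc3)c(=O)c2c1OC(C)C` reaches only a limit in a functional assay on MDA-MB-231 cells (Homo sapiens) for antiproliferative activity, read by sulforhodamine B assay, with a stated time of 72 h; a higher number here means a weaker inhibitor, a lower number a stronger inhibitor: compound 1 stands at > 10000 nM, which is a limit and not a number. For the measured compounds named here, compound 2 `O=C(/C=C/c1csc2ccccc12)c1ccccc1O` gives 5300 nM in this assay, the only actual number so far, so there is no second figure to rank it against. Compound 3 `CC(C)Oc1ccc(O)c(C(=O)/C=C/c2csc3ccccc23)c1` differs from compound 2 in one place: isopropoxy in place of hydrogen on an aromatic carbon, para to a hydroxy group. Going by the values given here, no step between measured compounds is available to size this change. Among the compounds with values here, a modest gain in potency, about the size of the scatter, is expected, and the only anchor is compound 2 at 5300 nM. The expected move is a 2.1-fold lower number from compound 2 to compound 3 (0.33 log units; beyond the scatter). For compound 3 the estimated value is 2500 nM, with an expected range of 700 nM to 9000 nM.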

Compound 3, half-maximal inhibitory concentration: 8500 nM
Compound 3: middle estimate off by 3.4-fold (0.53 log units), on the low side; the measured number falls inside the stated range.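

In this assay the series now has its first readable step, with isopropoxy in place of hydrogen on an aromatic carbon: a 1.6-fold higher number from compound 2 to compound 3 (0.21 log units; within the scatter), so this position, para to a hydroxy group, accepts the isopropoxy group and its 4 heavy atoms with no change that can be told from the scatter. The result gives no sign of a gain in potency from this change, though a single step cannot size the effect of this position in general. Any weaker analogue in this series may soon leave the range of actual numbers, and the evidence available on this point is only: the limit of > 10000 nM in this assay, at which 1 of the 3 values shown sits.

From the compounds shown here alone, whether a methoxy group, an amine or a carboxylic acid at the same position would move the number beyond the scatter stays open. Going by these compounds, the contribution of the hydroxy group para to this position stays open as well.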